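This account rests on a few compounds, and the source may have more. Where it says the series, first, only, none or still open, it means among the compounds named here.

Three compounds of the series have been run in a functional assay on LOX IMVI cells (Homo sapiens) for inhibition, read by sulforhodamine B assay, with a stated time of 48 h, tested at 10 uM; a lower number here means less inhibition, a higher number more inhibition at the concentration tested (going by the name of the read-out). Compound 1 `c1ccc(-c2cn3ccnc3c(-c3ccc4ncn(C5CCCCC5)c4c3)n2)cc1` gives 39.6%. Compound 2 `Fc1ccc(-c2cn3ccnc3c(-c3ccc4ncn(C5CCCCC5)c4c3)n2)cc1` gives 3.5%, and the step of a number 36.1 percentage points lower from compound 1 to compound 2 (beyond the scatter) is the largest seen so far. Compound 3 `Clc1ccc(-c2cn3ccnc3c(-c3ccc4ncn(C5CCCCC5)c4c3)n2)cc1` gives 14.8%; the step of a number 24.8 percentage points lower from compound 1 to compound 3 (beyond the scatter) is smaller, and a number 11.3 percentage points higher from compound 2 to compound 3 (beyond the scatter) sets compound 3 second highest of the three, between compound 2 and compound 1.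

Compound 4 `COc1ccccc1-c1cn2ccnc2c(-c2ccc3ncn(C4CCCCC4)c3c2)n1` is the next member: 2-methoxyphenyl in place of 4-chlorophenyl on an aromatic carbon. Among the compounds with values here, no measured step replaces one group on that aromatic carbon with another of a different kind, so the two halogen steps bear on it only loosely. They show that altering this aromatic carbon moves this assay by modest to large amounts, with the unsubstituted compound 1 highest. The expectation for compound 4 is therefore a modest step, most likely upward toward compound 1 but with the direction uncertain, estimated as a number 7.2 percentage points higher from compound 3 to compound 4 (within the scatter). Compound 4 is expected to give 22%, within 3% to 45%.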

Compound 4, a percentage reported as inhibition, at one concentration (the size of the read-out at that concentration, not a potency): 5.13%
Estimate against measurement, compound 4: 16.9 percentage points above; low and high end bracket the measured number.
By their numbers in this assay, from the lowest: compounds 2, 4 and 3 (each within the scatter of the next, the first and the last beyond it); then compound 1.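

In this assay, the 2-methoxyphenyl group of compound 4 shows that the low numbers are not confined to halogens at this position: the step is a number 34.5 percentage points lower from compound 1 to compound 4 (beyond the scatter), close in size to the fluoro step. The change from a halogen-bearing ring to 2-methoxyphenyl separates nothing, with a number 9.7 percentage points lower from compound 3 to compound 4 (within the scatter) and a number 1.6 percentage points higher from compound 2 to compound 4 (within the scatter). Among the compounds shown, all three substituted phenyl compounds thus lie beyond the scatter under the unsubstituted compound 1, and no compound goes against this. No available evidence accounts for this.

Open is whether the outcome depends on where the substituent stands, as 4-methoxyphenyl is not among the compounds shown. Also open, as far as these compounds go, is how this position responds to an amine or a carboxylic acid on the phenyl ring.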